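Methylsulfonyl in place of (trifluoromethyl)carbonyl on a nitrogen

The source may report more compounds than this note shows. Statements on the series, on what has been measured and on what is new or still open speak of the compounds shown alone.

In a physicochemical assay for lipophilicity (on this read-out higher numbers stand for higher lipophilicity and lower numbers for lower lipophilicity), compound 1 (`CC(C)c1cc([N+](=O)[O-])cc(C(C)C)c1O`) gives 4.71 as its reading. Going by the values given here, compound 2 (`CC(C)c1cc(NC(=O)C(F)(F)F)cc(C(C)C)c1O`) gives 4.46 on the same read-out, and that number lies within the usual scatter of the one for compound 1, so the two cannot be told apart. Compound 3 (`CC(C)c1cc(NS(C)(=O)=O)cc(C(C)C)c1O`) has not yet been measured. It shares its core with compound 2 and differs from it in one place by methylsulfonyl in place of (trifluoromethyl)carbonyl on a nitrogen on an aromatic ring in the exchange of methylsulfonyl in place of (trifluoromethyl)carbonyl on a nitrogen on an aromatic ring. Among the compounds with values here, no measured pair of compounds shows what this exchange does, so the expectation rests on the structural change alone and carries a wide range. In this assay a clear fall to a lower number is expected, well beyond the scatter, and the estimated size is a number 0.96 log units lower from compound 2 to compound 3 (beyond the scatter) in this account. For compound 3 the expected value is 3.5 with an estimated range from 3 to 4.1 for the coming measurement.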

Compound 3, partition coefficient: 3.14
Compound 3: middle estimate off by 0.36 log units, on the high side; measured number inside the range.
By their numbers in this assay, from the lowest: compound 3; then compounds 2 and 1 (each within the scatter of the next).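

In this assay, compounds 1 and 2 had stood within the scatter of each other, so the shared core had not yet shown any sensitivity to the group carried at this place. The exchange of (trifluoromethyl)carbonyl for methylsulfonyl on a nitrogen on an aromatic ring now gives a number 1.32 log units lower from compound 2 to compound 3 (beyond the scatter), and methanesulfonamido in place of nitro on an aromatic carbon gives a number 1.57 log units lower from compound 1 to compound 3 (beyond the scatter), which sets compound 3 apart from both earlier compounds and shows that the read-out can move widely with the group at this place. No measurement at hand accounts for the size of this fall, and the structures alone cannot assign it to any feature of the exchange.

The compounds shown leave open whether the fall follows from the sulfonyl group itself or from the departure of the trifluoromethyl group, a question that trifluoromethylsulfonyl or acetyl on the same nitrogen would address. They also leave open how a free amine at this place, or a longer chain such as ethylsulfonyl on the nitrogen, would read in this assay.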